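The source may report more compounds than this note shows. Statements on the series, on what has been measured and on what is new or still open speak of the compounds shown alone.

Working notes on the series, read in an ADME assay on Vero cells (Chlorocebus sabaeus) for cytotoxicity; a lower number here means that less compound is tolerated, a higher number that more compound is tolerated. Compound 1 (`O=C1C(=O)N(Cc2cn(CC(=O)N3CCN(c4cc5c(cc4F)c(=O)c(C(=O)O)cn5C4CC4)CC3)nn2)c2ccc(F)cc21`) gives 32 ug/mL, compound 2 (`CCO/N=C1/C(=O)N(Cc2cn(CC(=O)N3CCN(c4cc5c(cc4F)c(=O)c(C(=O)O)cn5C4CC4)CC3)nn2)c2ccc(C)cc21`) gives 32 ug/mL, and compound 3 (`CO/N=C1/C(=O)N(Cc2cn(CC(=O)N3CCN(c4cc5c(cc4F)c(=O)c(C(=O)O)cn5C4CC4)CC3)nn2)c2c(F)cccc21`) gives 32 ug/mL. Compound 2 therefore stands level with compound 1 and compound 3, with no difference in the reported values and nothing beyond the scatter.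

The next compound to be read is compound 4 (`CO/N=C1/C(=O)N(Cc2cn(CC(=O)N3CCN(c4cc5c(cc4F)c(=O)c(C(=O)O)cn5C4CC4)CC3)nn2)c2ccc(C)cc21`). Relative to compound 2, hydrogen stands in place of methyl on a saturated chain carbon bound to an oxygen on an unsaturated carbon, which turns ethoxy to methoxy: hydrogen in place of methyl on a saturated chain carbon bound to an oxygen on an unsaturated carbon. Among the compounds with values here, no measured pair differs in one place only, so this change has no direct precedent in this assay. The expectation rests only on the flat readings so far, with compound 2 at 32 ug/mL. The expected change, no change at the digits printed from compound 2 to compound 4 (within the scatter), stays within the scatter, with no direction favoured. For compound 4 the estimated value is 32 ug/mL, with an expected range of 16 ug/mL to 64 ug/mL.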

Compound 4, half-maximal cytotoxic concentration: 8 ug/mL
Estimate against measurement, compound 4: 4.0-fold (0.60 log units) above; measured number below the stated range.
By their numbers in this assay, from the lowest: compound 4; then compounds 1, 2 and 3 (each within the scatter of the next).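

In this assay, within the data shown here, ethoxy to methoxy gives a 4.0-fold lower number from compound 2 to compound 4 (0.60 log units; beyond the scatter) and is the first single-place step that can be read. The earlier compounds shown here, with their flat readings and no pair differing in one place, could not show that this position responds; here, on a saturated chain carbon bound to an oxygen on an unsaturated carbon, hydrogen in place of methyl moves the reading beyond the scatter. No measurement at hand bears on the cause of this step.

As far as these compounds go, whether the number tracks chain length remains open, since only ethoxy and methoxy can be compared here, and a longer chain such as propoxy or a bare hydroxyl would extend that comparison. From the compounds shown here alone, whether the step carries over to other substituents on the shared core also remains open.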